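Swapping bromo for methoxy on the benzylsulfanyl arm

The compounds below may be only part of what the source reports. "The series", "measured", "known", "first", "only" and "open" are said of these compounds alone.

Compound 1, `Cc1cc(Nc2cc(-c3cccs3)[nH]n2)n2nc(SCc3ccc(Br)cc3)nc2n1`: 4890 nM
Compound 2, `Cc1cc(Nc2cc(-c3ccccc3)[nH]n2)n2nc(SCc3ccc(Br)cc3)nc2n1`: 4760 nM
Compound 3, `CCCCCc1c(C)nc2nc(SCc3ccc(Cl)cc3)nn2c1Nc1cc(-c2ccccc2)[nH]n1`: > 50000 nM
Compound 4, `COc1ccc(CSc2nc3nc(C)cc(Nc4cc(-c5ccccc5)[nH]n4)n3n2)cc1`: not yet measured

Three compounds sharing one core have been run in a functional assay on PC-9 cells (Homo sapiens) for inhibition, read by MTT assay, with a stated time of 72 h; on this read-out higher numbers stand for weaker inhibition and lower numbers for stronger inhibition. Compound 1 gives 4890 nM. Compound 2 gives 4760 nM, and the step of a 1.0-fold lower number from compound 1 to compound 2 (0.01 log units; within the scatter) shows that phenyl in place of thiophen-2-yl on an aromatic carbon leaves the read-out essentially unchanged. Compound 3 yields only a limit of the assay, > 50000 nM, so its value is not a number; the same limit is recorded as the limit of > 50000 nM in this assay, at which 1 of the 3 values shown sits. Among the two numbers available, compound 2 stands at the lower one, though it sits within the scatter of compound 1.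

Compound 4 keeps everything of compound 2 except the change (methoxy in place of bromo on an aromatic carbon). Among the measured compounds shown here, no measured step touches that part of the molecule: the single step on record, from compound 1 to compound 2, concerns the aryl group on the pyrazole and was within the scatter, and compound 3 differs from compound 2 in more than one place. Nothing therefore argues for a large move in either direction in this assay, and the expectation is a step of a 1.3-fold higher number from compound 2 to compound 4 (0.10 log units; within the scatter) that stays within the scatter. Compound 4 is estimated at 6000 nM, with a range from 2500 nM to 15000 nM.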

Compound 4, half-maximal inhibitory concentration: 8110 nM
For compound 4 the middle estimate is 1.4-fold (0.13 log units) below the measured one; the range from low to high includes it.
By their numbers in this assay, from the lowest: compounds 2, 1 and 4 (each within the scatter of the next). At a limit, above all of these: compound 3.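

In this assay, among the compounds shown here, exchanging the (4-bromobenzyl)sulfanyl arm for the (4-methoxybenzyl)sulfanyl arm gives a 1.7-fold higher number from compound 2 to compound 4 (0.23 log units; within the scatter), the first reading at this position, where methoxy in place of bromo leaves the result within the usual variation between repeats. With a 1.0-fold lower number from compound 1 to compound 2 (0.01 log units; within the scatter), there are now two single-place changes on this core, one on the aryl group of the pyrazole and one on the benzyl arm, and neither moves the read-out beyond the scatter. Nothing measured here gives a reason for the result at this position.

On these data alone, only bromo and methoxy have been compared at this position, so it remains open whether a carboxylic acid, an amine or a longer chain there would give a step beyond the scatter, or whether a plain benzyl arm carrying only hydrogen would read like compound 2 and compound 4. Compound 3 gives only a limit of the assay, > 50000 nM, and as it differs from compound 2 in more than one place, that limit cannot be assigned to any single change.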